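A few compounds are considered here, and "the series" means these few. Any claim that something is new, unique, unknown or untested is made for them only; others in the source may bear on it.

Compound 1 `Cc1nc(-c2cccc(C(=O)N3CCCC(C(=O)Nc4ccc(Cl)cc4)C3)c2)no1` shows no measurable cytotoxicity in an ADME assay on PC-3 cells (Homo sapiens) for cytotoxicity, read by WST assay, tested at 100 uM; a lower number here means less inhibition, a higher number more inhibition at the concentration tested (going by the name of the read-out): compound 1 gives 0%. Compound 2 `CC(=O)c1cccc(NC(=O)C2CCCN(C(=O)c3cc(C(F)(F)F)cc(C(F)(F)F)c3)C2)c1` gives 0% and compound 3 `C=CCOc1cccc(NC(=O)C2CCCN(C(=O)c3cc(C(F)(F)F)cc(C(F)(F)F)c3)C2)c1` gives 0%, so compound 1 stands level with both at the digits shown. Within the data shown here, the only measured step, no change at the digits printed from compound 2 to compound 3 (within the scatter), is an exchange of allyloxy for acetyl on an aromatic carbon and touches a different part of the shared core; it bears on compound 4 `O=C(Nc1ccc(Cl)cc1)C1CCCN(C(=O)c2cccc(-c3cnco3)c2)C1` only by showing that this series sits at the floor of the read-out. The change from compound 1 is 1,3-oxazol-5-yl in place of 5-methyl-1,2,4-oxadiazol-3-yl on an aromatic carbon. With every measured compound at the floor, the step of no change at the digits printed from compound 1 to compound 4 (within the scatter) is expected to be flat, within the scatter. Compound 4 is therefore estimated at 0%, range -10% to 10%.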

Compound 4, a percentage reported as inhibition, at one concentration (the size of the read-out at that concentration, not a potency): 0%
Compound 4: middle estimate and measured number agree at the digits printed; the range from low to high includes it.
By their numbers in this assay, from the lowest: compounds 1, 2, 3 and 4 (each within the scatter of the next).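

In this assay the swap to 1,3-oxazol-5-yl on the aromatic carbon meta to a large group shows no change at the digits printed from compound 1 to compound 4 (within the scatter) and is the only step shown at this position. A five-membered aromatic ring with 2 hetero atoms and one with 3 hetero atoms thus read alike here, both at the floor of the read-out. No evidence on the cause of this flat result is available. Open, as far as these compounds go, is whether an amine or a carboxylic acid at this aromatic carbon would lift the read-out off the floor.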